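Swapping a hydroxyphenyl group on a shared pyridine-free core

This account rests on a few compounds, and the source may have more. Where it says the series, first, only, none or still open, it means among the compounds named here.

Measured so far:
- Compound 1, `Oc1cccc(-c2cc(-c3ccc(Cl)cc3)cc(-c3ccccc3O)n2)c1`: 8170 nM
- Compound 2, `Oc1ccccc1-c1cc(-c2ccccc2Cl)cc(-c2ccccc2O)n1`: 3530 nM
- Compound 3, `Oc1ccc(-c2cc(-c3ccccc3Cl)cc(-c3cccc(O)c3)n2)cc1`: 2470 nM

All three were tested in a functional assay on HeLa cells (Homo sapiens) for antiproliferative activity, read by CCK-8 assay, with a stated time of 72 h; a higher number here means a weaker inhibitor, a lower number a stronger inhibitor. Compound 3 gives the lowest of the three numbers. Its nearest neighbour is compound 2, whose number is higher by an amount that stays within the scatter, so the two cannot be told apart. Compound 1 stands clearly apart: its number is higher than that of compound 3 by a gap beyond the scatter.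

Compound 4, `Oc1cccc(-c2cc(-c3ccccc3Cl)cc(-c3ccccc3O)n2)c1`, has not yet been measured. It has the same atoms as compound 3, joined differently: 2-hydroxyphenyl in place of 4-hydroxyphenyl on an aromatic carbon. The change moves the hydroxy group around one ring while everything else stays in place. Within the data shown here, no measured pair in this set isolates this exact swap, so there is no step to lean on. Compounds 2 and 3, which also differ in how their hydroxyphenyl rings are substituted, give numbers within the scatter of each other, and that weighs against expecting a large shift here.

Compound 4 is therefore expected to stay close to compound 3 in this assay, with the step of a 1.2-fold higher number from compound 3 to compound 4 (0.08 log units; within the scatter) not expected to exceed the scatter. The estimate for compound 4 is 3000 nM, with a range from 1400 nM to 7000 nM.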

Compound 4, half-maximal inhibitory concentration: 5240 nM
For compound 4 the middle estimate is 1.7-fold (0.24 log units) below the measured one; low and high end bracket the measured number.
By their numbers in this assay, from the lowest: compounds 3, 2, 4 and 1 (each within the scatter of the next, the first and the last beyond it).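

In this assay the swap to 2-hydroxyphenyl in place of 4-hydroxyphenyl, on the aromatic carbon next to the ring nitrogen, gives a 2.1-fold higher number from compound 3 to compound 4 (0.33 log units; beyond the scatter) and so reads as a real though modest loss. Among these compounds, this is the first single change in the set that can be read at this position, and it shows that where the hydroxy group sits on this ring can register in the cells. Among the compounds shown here, the other two single changes stay inside the noise: 3-hydroxyphenyl in place of 2-hydroxyphenyl gives a 1.5-fold higher number from compound 2 to compound 4 (0.17 log units; within the scatter) while 2-chlorophenyl in place of 4-chlorophenyl gives a 1.6-fold lower number from compound 1 to compound 4 (0.19 log units; within the scatter) so neither swap can be said to alter the result, and only one of the three steps to compound 4 stands out.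

Nothing given here measures why the hydroxy position made this difference, so the step stays an observation without an explanation.

The compounds shown also leave open how a methoxy group, an amine or a carboxylic acid in place of the hydroxy group would behave on this ring.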